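Swapping the aryl group on the four-membered core

The source may hold more compounds than are shown below. What is called first, only, known or untested is meant among the compounds shown, and "the series" means these compounds.

Compound 2 `COc1cc(N2C(=O)[C@@H](Oc3ccccc3)[C@H]2c2ccc(O)cc2)cc(OC)c1OC`: 48000 nM
Compound 1 `COc1cc(N2C(=O)[C@@H](Oc3ccccc3)[C@H]2c2ccc(C#N)cc2)cc(OC)c1OC`: 31600 nM

In a functional assay on MCF7 cells (Homo sapiens) for antiproliferative activity, read by MTT assay, with stated times of 24 h and 72 h (on this read-out lower numbers stand for stronger inhibition and higher numbers for weaker inhibition), compound 2 stands highest of the two numbers, with compound 1 nearest at a 1.5-fold higher number from compound 1 to compound 2 (0.18 log units; within the scatter). Compound 3 `COc1ccc([C@@H]2[C@H](Oc3ccccc3)C(=O)N2c2cc(OC)c(OC)c(OC)c2)cc1N` is not yet measured. Relative to compound 2 it carries 3-amino-4-methoxyphenyl in place of 4-hydroxyphenyl on a saturated ring carbon. Going by the values given here, the only measured step touches the same saturated ring carbon, and a 1.5-fold higher number from compound 1 to compound 2 (0.18 log units; within the scatter) was within the scatter, so the change to compound 3 is expected to give no step beyond the scatter, wide uncertainty included. Compound 3 is therefore estimated at 20000 nM in this assay, within 3000 nM to 130000 nM, meaning an expected 2.4-fold lower number from compound 2 to compound 3 (0.38 log units; beyond the scatter).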

Compound 3, half-maximal inhibitory concentration: 12200 nM
The estimate for compound 3 lay 1.6-fold (0.21 log units) above the measured number; low and high end bracket the measured number.
By their numbers in this assay, from the lowest: compound 3; then compounds 1 and 2 (each within the scatter of the next).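

In this assay the saturated ring carbon now shows steps beyond the scatter: 3-amino-4-methoxyphenyl in place of 4-hydroxyphenyl gives a 3.9-fold lower number from compound 2 to compound 3 (0.59 log units; beyond the scatter), and in place of 4-cyanophenyl it gives a 2.6-fold lower number from compound 1 to compound 3 (0.41 log units; beyond the scatter). Going by these compounds alone, the earlier change at this carbon stayed within the scatter, so this is the first aryl group here that separates from both others, though both steps are modest. Nothing available here accounts for this difference. The compounds shown leave open whether the amino or the methoxy group carries the step, and whether a carboxylic acid in place of the amino group would keep it.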